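Toward Compound 4: Swapping a Cyclohexyl for an Aryl Group

A few compounds are considered here, and "the series" means these few. Any claim that something is new, unique, unknown or untested is made for them only; others in the source may bear on it.

Measured in an ADME assay on microsomes from liver (Homo sapiens) for pharmacokinetics, read by LC-MS, using NADPH, with a stated time of 30 min, tested at 1 uM (on this read-out higher numbers stand for fast clearance and lower numbers for slow clearance), so far:
- compound 1 `CC[C@H]1CC[C@H](C2=NC3(CCN(S(=O)(=O)CCc4c(C)cc(N(C)C(N)=O)cc4C)CC3)C(=O)N2)CC1` gives 170 mL.min-1.g-1
- compound 2 `Cc1cc(N(C)C(N)=O)cc(C)c1CCS(=O)(=O)N1CCC2(CC1)N=C(c1ccc(OC(F)(F)F)cc1)NC2=O` gives 48 mL.min-1.g-1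
- compound 3 `Cc1cc(N2C(=O)CNC2=O)cc(C)c1CCS(=O)(=O)N1CCC2(CC1)N=C([C@H]1CC[C@H](C)CC1)NC2=O` gives 53 mL.min-1.g-1

The number for compound 3 lies within the scatter of the number for compound 2, and both lie clearly under the number for compound 1.

Compound 4 `Cc1cc(N2C(=O)CNC2=O)cc(C)c1CCS(=O)(=O)N1CCC2(CC1)N=C(c1ccc(OC(F)(F)F)cc1)NC2=O` differs from compound 3 by 4-(trifluoromethoxy)phenyl in place of 4-methylcyclohexyl on a carbon with a double bond to nitrogen.

Within the data shown here, one measured step bears on this change. The same group entered at the same place, replacing 4-ethylcyclohexyl, in a 3.5-fold lower number from compound 1 to compound 2 (0.55 log units; beyond the scatter), a modest drop beyond the scatter. That single step comes from a pair that also differs from compound 3 elsewhere in the structure, so it is only a rough guide.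

A similar move to a lower number in this assay is therefore expected, with an estimated 2.7-fold lower number from compound 3 to compound 4 (0.42 log units; beyond the scatter).

For compound 4 the estimated value is 20 mL.min-1.g-1, with an expected range of 9 mL.min-1.g-1 to 45 mL.min-1.g-1.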

Compound 4, intrinsic clearance in microsomes: 110 mL.min-1.g-1
Estimate against measurement, compound 4: 5.5-fold (0.74 log units) below, outside the stated range (above it).
By their numbers in this assay, from the lowest: compounds 2 and 3 (each within the scatter of the next); then compounds 4 and 1 (each within the scatter of the next).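

In this assay, 4-(trifluoromethoxy)phenyl in place of 4-methylcyclohexyl gave a rise (a 2.1-fold higher number from compound 3 to compound 4 (0.32 log units; beyond the scatter)), whereas the same group replacing 4-ethylcyclohexyl had given a drop (a 3.5-fold lower number from compound 1 to compound 2 (0.55 log units; beyond the scatter)). The change at this carbon with a double bond to nitrogen therefore has no single direction across these two pairs. With the 4-(trifluoromethoxy)phenyl group held constant, 2,5-dioxoimidazolidin-1-yl in place of carbamoyl(methyl)amino on the aromatic carbon also raised the number (a 2.3-fold higher number from compound 2 to compound 4 (0.36 log units; beyond the scatter)), and nothing available gives a reason for either rise.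

The compounds shown do not separate the part played by the group on the aromatic carbon from that of the methyl or ethyl on the cyclohexyl ring. They also leave open how an amine or a carboxylic acid on the phenyl ring would behave at this position.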